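This account rests on a few compounds, and the source may have more. Where it says the series, first, only, none or still open, it means among the compounds named here.

Measured compounds: compound 1, `COc1ccc2c(c1)/C(=C1/Nc3ccccc3/C1=N\O)C(=O)N2Cc1ccc(/C=C/C(=O)NO)cc1`, 50 nM; compound 2, `O=C(NO)c1ccc(CN2C(=O)/C(=C3\Nc4ccccc4\C3=N/O)c3cc(Br)ccc32)cc1`, 7 nM.

Going by the values given here, compound 1 is one of two compounds measured in a functional assay on NCI-H23 cells (Homo sapiens) for cytotoxicity, read by colorimetric assay (on this read-out higher numbers stand for weaker inhibition and lower numbers for stronger inhibition), and among them it has the higher number; the lower number belongs to compound 2, and the gap between the two lies beyond the scatter. Compound 3, `Cc1ccc2c(c1)/C(=C1/Nc3ccccc3/C1=N\O)C(=O)N2Cc1ccc(/C=C/C(=O)NO)cc1`, is not yet measured. It differs from compound 1 in one place: methyl in place of methoxy on an aromatic carbon. Among the compounds with values here, since no pair of measured compounds shows this change, its effect is unknown, and the step of no change at the digits printed from compound 1 to compound 3 (within the scatter) is expected to stay within the scatter. Compound 3 is therefore estimated at 50 nM, with a range from 20 nM to 130 nM.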

Compound 3, half-maximal inhibitory concentration: 10 nM
Beside the measured number, compound 3's estimate is 5.0-fold (0.70 log units) above it; measured number below the stated range.
By their numbers in this assay, from the lowest: compounds 2 and 3 (each within the scatter of the next); then compound 1.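

In this assay, going by these compounds alone, this is the first pair to isolate a single change at this position on the six-membered aromatic ring, and it shows that the position responds to its substituent: methyl in place of methoxy gives a modest step, a 5.0-fold lower number from compound 1 to compound 3 (0.70 log units; beyond the scatter). No measurement shown here accounts for this step.

Going by these compounds, what remains open is how an amine, a carboxylic acid or a longer chain such as ethyl would behave at this position. This single pair also cannot show whether the same change would give a similar step elsewhere on the shared core.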